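Ester to piperidinyl amide on the shared core

This account rests on a few compounds, and the source may have more. Where it says the series, first, only, none or still open, it means among the compounds named here.

Compound 3 `COC(=O)c1c(N)sc(-c2ccc(Cl)cc2)c1-c1ccc(Cl)cc1` gives 5040 nM in a functional assay on A549 cells (Homo sapiens) for inhibition, read by sulforhodamine B assay, with a stated time of 72 h (a higher number here means a weaker inhibitor, a lower number a stronger inhibitor), the highest number among the three measured compounds. Compound 1 `Nc1sc(-c2ccc(Cl)cc2)c(-c2ccc(Cl)cc2)c1C(=O)N1CCNCC1` gives 1020 nM in this assay, and compound 2 `Nc1sc(-c2ccc(Cl)cc2)c(-c2ccc(Cl)cc2)c1C(=O)N1CCCCC1=O` gives 1820 nM. The two steps that end at compound 3, a 4.9-fold higher number from compound 1 to compound 3 (0.69 log units; beyond the scatter) and a 2.8-fold higher number from compound 2 to compound 3 (0.44 log units; beyond the scatter), both go beyond the scatter, whereas the step of a 1.8-fold higher number from compound 1 to compound 2 (0.25 log units; within the scatter) stays within it. On these numbers, methoxy on the carbonyl carbon is the weakest of the three variants, and the two amides are not separated from each other.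

Compound 4 `Nc1sc(-c2ccc(Cl)cc2)c(-c2ccc(Cl)cc2)c1C(=O)N1CCCCC1` is the unmeasured member. Its difference from compound 3: piperidin-1-yl in place of methoxy on a carbonyl carbon. Both measured steps that bear on this change run the other way, from an amide on the carbonyl carbon to methoxy, and both raise the number modestly. Reversing that direction, a drop beyond the scatter is expected for compound 4 in this assay, of about the size seen in a 2.8-fold higher number from compound 2 to compound 3 (0.44 log units; beyond the scatter) to a 4.9-fold higher number from compound 1 to compound 3 (0.69 log units; beyond the scatter). The estimate for compound 4 is 1400 nM, with a range from 600 nM to 3500 nM. The expected step from compound 3 is a 3.6-fold lower number from compound 3 to compound 4 (0.56 log units; beyond the scatter).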

Compound 4, half-maximal inhibitory concentration: 4620 nM
Estimate against measurement, compound 4: 3.3-fold (0.52 log units) below; measured number above the stated range.
By their numbers in this assay, from the lowest: compounds 1 and 2 (each within the scatter of the next); then compounds 4 and 3 (each within the scatter of the next).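

In this assay, swapping methoxy for piperidin-1-yl on the carbonyl carbon gives a 1.1-fold lower number from compound 3 to compound 4 (0.04 log units; within the scatter), so an amide at this place does not by itself lower the number, and compound 4 stays level with the ester compound 3. The two earlier amides stand apart from it, with a 2.5-fold higher number from compound 2 to compound 4 (0.40 log units; beyond the scatter) and a 4.5-fold higher number from compound 1 to compound 4 (0.66 log units; beyond the scatter), so the lower numbers of compounds 1 and 2 go with what their rings carry beyond the plain piperidine ring, the ring amine of piperazin-1-yl or the ring carbonyl of 2-oxopiperidin-1-yl, and not with the amide link alone. Nothing measured here accounts for this split.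

The compounds shown leave open whether the ring amine is needed as such or whether another ring hetero atom would serve as well, which morpholin-4-yl or 4-methylpiperazin-1-yl on the same carbonyl carbon would test. Also open, from the compounds shown here alone, is whether a ring is needed at all, a question for an open-chain amide ending in an amine or for the free carboxylic acid.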